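The source may hold more compounds than are shown below. What is called first, only, known or untested is meant among the compounds shown, and "the series" means these compounds.

Compound 2 is `CCCCCCc1ccc(-c2c(C)[nH]c(=O)n2C)cc1`. In a functional assay on brain (Rattus norvegicus, strain Wistar) for inhibition (a higher number here means a weaker inhibitor, a lower number a stronger inhibitor), compound 2 gives 9000 nM. Among the measured compounds shown here, the only other number comes from compound 1, which is `Cc1[nH]c(=O)n(C)c1-c1ccc(OCCC(C)C)cc1`; in this assay compound 1 gives 6600 nM. For the measured compounds named here, compound 2 therefore stands alongside compound 1 rather than apart from it: the one measured step, a 1.4-fold higher number from compound 1 to compound 2 (0.13 log units; within the scatter), is within the scatter, so the two compounds cannot be told apart on these numbers.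

Compound 3 is `Cc1[nH]c(=O)n(C)c1-c1ccc(Oc2ccccc2)cc1`. It differs from compound 2 as follows: phenoxy in place of hexyl on an aromatic carbon

Going by the values given here, only one measured step bears on this change, and only loosely. Among the compounds with values here, the step of a 1.4-fold higher number from compound 1 to compound 2 (0.13 log units; within the scatter) swaps one chain on that aromatic carbon for another and stays within the scatter; no measured step swaps a chain for a phenoxy. With no step beyond the scatter at that position, compound 3 is expected to give a number in this assay close to that of compound 2, with the step of a 1.1-fold lower number from compound 2 to compound 3 (0.05 log units; within the scatter) expected to stay within the scatter. Compound 3 is thus estimated at 8000 nM, between 2500 nM and 25000 nM, pending its measurement.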

Compound 3, half-maximal inhibitory concentration: 8100 nM
Compound 3: middle estimate off by 1.0-fold (0.01 log units), on the low side; the measured number falls inside the stated range.
By their numbers in this assay, from the lowest: compounds 1, 3 and 2 (each within the scatter of the next).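

The ring result is what compound 3 adds: until now only open chains had stood on this aromatic carbon, and in this assay the exchange of hexyl for phenoxy, which brings in a six-membered aromatic ring and a hydrogen-bond acceptor, gives a 1.1-fold lower number from compound 2 to compound 3 (0.05 log units; within the scatter) and so leaves the number unresolved from that of the chain. The same holds with the oxygen kept in place, where phenyl on that oxygen instead of isopentyl gives a 1.2-fold higher number from compound 1 to compound 3 (0.09 log units; within the scatter) and the ring again cannot be told apart from the branched chain. Across these three compounds, then, neither the ring, nor the oxygen, nor the form of the chain separates one number from another in this assay, and nothing available offers an account of this result.

Going by these compounds, what remains open is whether any group on this carbon moves the number beyond the scatter, for instance an amine, a carboxylic acid or a much shorter chain such as methyl. All three compounds also share the same core, so they leave open what a change to the core or to its two methyl groups would do.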